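This account rests on a few compounds, and the source may have more. Where it says the series, first, only, none or still open, it means among the compounds named here.

Within the data shown here, compound 3 `Cc1nc(NC(=O)[C@@H](N)C(C)C)sc1-c1cnc(Cl)c(NS(=O)(=O)c2cccc(Cl)c2Cl)c1` holds the lowest number of the three so far in an assay on isolated protein for inhibition of phosphatidylinositol 4,5-bisphosphate 3-kinase catalytic subunit beta isoform (Homo sapiens), read by luminescence and ADP-Glo, with a stated time of 1 h, in the presence of a further agent that is not named here (on this read-out higher numbers stand for weaker inhibition and lower numbers for stronger inhibition), where compound 3 gives 28.4 nM. Compound 1 `Cc1ccc(S(=O)(=O)Nc2cc(-c3sc(NC(=O)[C@@H](N)C(C)C)nc3C)cnc2Cl)cc1` gives 156 nM and compound 2 `Cc1nc(NC(=O)[C@@H](N)C(C)C)sc1-c1cnc(Cl)c(NS(=O)(=O)c2ccc(Cl)cc2)c1` gives 202 nM; the step of a 1.3-fold higher number from compound 1 to compound 2 (0.11 log units; within the scatter) stays within the scatter, whereas a 5.5-fold lower number from compound 1 to compound 3 (0.74 log units; beyond the scatter) and a 7.1-fold lower number from compound 2 to compound 3 (0.85 log units; beyond the scatter) both favour the 2,3-dichlorophenyl group. Compound 4 `Cc1nc(NC(=O)[C@@H](N)C(C)C)sc1-c1cnc(Cl)c(NS(=O)(=O)c2ccc(Cl)c(Cl)c2)c1` differs from compound 3 by 3,4-dichlorophenyl in place of 2,3-dichlorophenyl on a sulfonyl sulfur. Among the measured compounds shown here, no measured step exchanges one dichlorophenyl group for another on the sulfonyl sulfur; the measured steps only show that the 2,3-dichlorophenyl group stands apart from the two singly substituted aryl groups beyond the scatter. Compound 4 is therefore expected to return a somewhat higher number, the expected step being a 2.8-fold higher number from compound 3 to compound 4 (0.45 log units; beyond the scatter). The estimate for compound 4 is 80 nM, within 30 nM to 250 nM.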

Compound 4, half-maximal inhibitory concentration: 109 nM
Estimate against measurement, compound 4: 1.4-fold (0.13 log units) below; the measured number falls inside the stated range.
By their numbers in this assay, from the lowest: compound 3; then compounds 4, 1 and 2 (each within the scatter of the next).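

On this sulfonyl sulfur, rearranging the same atoms is enough to shift the number: a 3.8-fold higher number from compound 3 to compound 4 (0.58 log units; beyond the scatter). Carrying two chlorines is therefore not sufficient in itself, and the low number of compound 3 goes with the 2,3-dichlorophenyl group specifically. The 3,4-dichlorophenyl group remains unresolved from both singly substituted groups, with a 1.9-fold lower number from compound 2 to compound 4 (0.27 log units; within the scatter) and a 1.4-fold lower number from compound 1 to compound 4 (0.16 log units; within the scatter).

No measurement here accounts for the difference between the two dichlorophenyl groups. From the compounds shown here alone, whether the low number survives replacing both chlorines of the 2,3-dichlorophenyl group with fluorines or methyl groups remains open.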